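The source may hold more compounds than are shown below. What is called first, only, known or untested is meant among the compounds shown, and "the series" means these compounds.

Measured so far:
compound 2, `c1cnc2nc(Oc3ccc4c(CN5CCCCC5)coc4c3)sc2c1` — 4.6 nM
compound 1, `c1ccc2sc(Oc3ccc4oc(CN5CCCCC5)cc4c3)nc2c1` — 330 nM

In an in vitro assay on Sf9 cells for inhibition of leukotriene A-4 hydrolase (Homo sapiens), read by immunoassay, with stated times of 10 min and 30 min (a higher number here means a weaker inhibitor, a lower number a stronger inhibitor), compound 2 gives 4.6 nM, the lower of the two numbers in hand. Within the data shown here, the other measured compound differs from compound 2 in the core rather than at one place; in this assay compound 1 gives 330 nM, the gap between the two lies well beyond the usual scatter, and no single-point step between them is defined, so the two values are simply recorded side by side.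

The next compound, compound 3, `O=C(O)C1CCN(Cc2coc3cc(Oc4nc5ncccc5s4)ccc23)CC1`, keeps the whole of compound 2 and changes it at one place: carboxy in place of hydrogen on a saturated ring carbon, that is, piperidin-1-yl to 4-carboxypiperidin-1-yl.

Among the measured compounds shown here, no measured pair isolates this change, so the expectation rests on compound 2 alone. The step from compound 2 to compound 3 in this assay is expected to be small, near or within the scatter, and if anything toward a lower number, estimated as a 1.3-fold lower number from compound 2 to compound 3 (0.12 log units; within the scatter). For compound 3 the estimate in this assay is 3.5 nM, expected to fall between 1 nM and 15 nM.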

Compound 3, half-maximal inhibitory concentration: 8.3 nM
The estimate for compound 3 lay 2.4-fold (0.38 log units) below the measured number, within the range that was stated.
By their numbers in this assay, from the lowest: compounds 2 and 3 (each within the scatter of the next); then compound 1.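

Notes on the piperidine position: in this assay there is now a first single-place step in the series, and carboxy in place of hydrogen on the saturated ring carbon gives a 1.8-fold higher number from compound 2 to compound 3 (0.26 log units; within the scatter) for this change. Piperidin-1-yl and 4-carboxypiperidin-1-yl therefore cannot be told apart in this read-out, which the earlier compounds could not show, as they offered no pair differing in one place. This carbon, three ring bonds from the ring nitrogen, thus accepts the carboxy group with the number staying within the scatter of the unsubstituted ring, on this core at least. Nothing in hand gives a reason for this outcome.

Open, as far as these compounds go, is whether a primary amide or a methyl ester on the same carbon, or a longer chain ending in a carboxylic acid, would also stay within the scatter of compound 3. Equally open, from the compounds shown here alone, is whether the change from piperidin-1-yl to 4-carboxypiperidin-1-yl keeps its size on the core of compound 1.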